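A few compounds are considered here, and "the series" means these few. Any claim that something is new, unique, unknown or untested is made for them only; others in the source may bear on it.

Compound 1 `COc1cc(OC)c(-c2coc3cc(OCC=C(C)C)ccc3c2=O)cc1OC` gives 3500 nM in a functional assay on U-251 cells (Homo sapiens) for antiproliferative activity, read by MTT assay, with a stated time of 24 h; a higher number here means a weaker inhibitor, a lower number a stronger inhibitor. Compound 2 `C=CCOc1ccc2c(=O)c(-c3cc(OC)c(OC)cc3OC)coc2c1` gives 5900 nM. Compound 3 `COc1ccc2c(=O)c(-c3cc(OC)c(OC)cc3OC)coc2c1` gives 9400 nM.

Compound 3 stands at the highest number of the three: its gap to compound 2 lies within the scatter, while a 2.7-fold higher number from compound 1 to compound 3 (0.43 log units; beyond the scatter) lies beyond it. Compound 4 `COc1cc(OC)c(-c2coc3cc(OCc4ccc([N+](=O)[O-])cc4)ccc3c2=O)cc1OC` differs from compound 3 by 4-nitrophenyl in place of hydrogen on a saturated chain carbon bound to an oxygen on an aromatic ring. Going by the values given here, the steps that bear on this change sit at the same place: a 1.6-fold higher number from compound 2 to compound 3 (0.20 log units; within the scatter) and a 2.7-fold higher number from compound 1 to compound 3 (0.43 log units; beyond the scatter), each showing a higher number as the group there shrinks to hydrogen. A larger group entering at that carbon is therefore expected to bring a modestly lower number in this assay, a step of about a 2.7-fold lower number from compound 3 to compound 4 (0.43 log units; beyond the scatter). Compound 4 is expected at 3500 nM, within a range from 1500 nM to 8000 nM.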

Compound 4, half-maximal inhibitory concentration: 9400 nM
Compound 4: the middle estimate sits 2.7-fold (0.43 log units) below what was measured; the measured number lies above the stated range.
By their numbers in this assay, from the lowest: compounds 1, 2, 3 and 4 (each within the scatter of the next, the first and the last beyond it).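

In this assay the 4-nitrophenyl group at this carbon shows no change at the digits printed from compound 3 to compound 4 (within the scatter) and does not bring the lower number that the vinyl and 2-methylprop-1-en-1-yl groups pointed to, while a 1.6-fold higher number from compound 2 to compound 4 (0.20 log units; within the scatter) also leaves it within the scatter of the vinyl compound. The size of the group alone therefore does not order these compounds, as exchanging 2-methylprop-1-en-1-yl for 4-nitrophenyl gives a 2.7-fold higher number from compound 1 to compound 4 (0.43 log units; beyond the scatter) even though the group grows. Nothing at hand explains this result.

On these data alone, whether an unsubstituted phenyl, or an amine or carboxylic acid in place of the nitro group, would change the number remains open.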